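Adding a Methyl Group: Expected Stability of Compound 4

A few compounds are considered here, and "the series" means these few. Any claim that something is new, unique, unknown or untested is made for them only; others in the source may bear on it.

Of the compounds shown here, three have been measured in an ADME assay on liver (Homo sapiens) for metabolic stability, read by LC-MS, using microsomes and NADPH; on this read-out lower numbers stand for a less stable compound and higher numbers for a more stable compound. Compound 1 `CCCN(Cc1ccc(OCCN2C(=O)CCC2=O)c(C)c1)C(CC(=O)O)c1ccc(Cl)cc1` gives 85%, and compound 2 `CCN(Cc1ccc(OCCN2C(=O)CCC2=O)c(C)c1)C(CC(=O)O)c1ccc(Cl)cc1` gives 100%. For the measured compounds named here, the single change between them, (methyl in place of hydrogen on a saturated chain carbon, two bonds along the chain from an amine nitrogen), made a step of a number 15 percentage points lower from compound 2 to compound 1 (beyond the scatter). Compound 3 `Cc1cc(CN(CC2CCCC2)[C@@H](CC(=O)O)c2ccc(Cl)cc2)ccc1OCCN1C(=O)CCC1=O` gives 78%; its value and that of compound 1 lie within the usual scatter of each other, while compound 2 stands beyond the scatter above compound 3. How the core of compound 2 differs from the core of compound 3 is not broken down here.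

Compound 4 `CCc1cc(CN(CC2CCCC2)[C@@H](CC(=O)O)c2ccc(Cl)cc2)ccc1OCCN1C(=O)CCC1=O` is not yet measured. Going by the values given here, it differs from compound 3 by methyl in place of hydrogen on a saturated chain carbon bound to an aromatic carbon, the same kind of change as the one made from compound 2 to compound 1, but at another place: there the methyl entered two bonds along the chain from an amine nitrogen, here it enters on a saturated chain carbon bound to an aromatic carbon. Because the earlier step of a number 15 percentage points lower from compound 2 to compound 1 (beyond the scatter) was a modest loss, a step of similar or somewhat smaller size is expected here, a number 10 percentage points lower from compound 3 to compound 4 (within the scatter), though a single example at a different place is a thin basis. Compound 4 is therefore estimated at 68%, within a range from 50% to 86%.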

Compound 4, percent of the compound remaining: 48%
The estimate for compound 4 lay 20 percentage points above the measured number; the measured number lies below the stated range.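

In this assay, putting methyl in place of hydrogen on a saturated chain carbon bound to an aromatic carbon gives a number 30 percentage points lower from compound 3 to compound 4 (beyond the scatter). Both steps with this change go downward, but their size does not carry over, so a step seen on one core is a poor guide to the size of the step on another: the same change on two cores in this assay, a number 15 percentage points lower (beyond the scatter) from compound 2 to compound 1 and a number 30 percentage points lower (beyond the scatter) from compound 3 to compound 4, 15 percentage points apart, beyond the scatter of two such steps. This does not show why the two differ: the methyl enters at a different place in each pair and the cores differ as well, so these pairs cannot separate the effect of place from that of core, and two steps make no rule for the series.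

The compounds shown leave open how large the step from methyl to ethyl would be on the core of compound 2, where the rest of the molecule differs from that of compound 3. They also leave open how a longer chain such as propyl, or a fluorine or hydroxyl on that chain carbon, would read out in this assay.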